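Octyl in place of an aryl group: notes on the series

A few compounds are considered here, and "the series" means these few. Any claim that something is new, unique, unknown or untested is made for them only; others in the source may bear on it.

- compound 1 `COc1ccc(-n2cc(COc3ccc(/C=C/C(=O)c4cc5c(cc4O)OC(C)(C)CC5)cc3)nn2)c([N+](=O)[O-])c1`: "not active" (no number reported)
- compound 2 `CC1(C)CCc2c(ccc(C(=O)/C=C/c3ccc(OCc4cn(-c5ccc(Br)cc5)nn4)cc3)c2O)O1`: 117000 nM
- compound 3 `CCc1ccccc1-n1cc(COc2ccc(/C=C/C(=O)c3ccc4c(c3O)CCC(C)(C)O4)cc2)nn1`: "not active" (no number reported)

All three compounds were tested in a functional assay on IMR-32 cells (Homo sapiens) for antiproliferative activity, read by MTT assay; on this read-out lower numbers stand for stronger inhibition and higher numbers for weaker inhibition. Compound 1 has no single number there: it is reported as "not active" (no number reported), and compound 3 likewise gives "not active" (no number reported). Within the data shown here, the only number belongs to compound 2, at 117000 nM, so compound 1 can be placed only qualitatively, without a numerical gap to compound 2.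

The next compound is compound 4 `CCCCCCCCn1cc(COc2ccc(/C=C/C(=O)c3cc4c(cc3O)OC(C)(C)CC4)cc2)nn1`. The change is octyl in place of 4-methoxy-2-nitrophenyl on an aromatic nitrogen. Among the measured compounds shown here, all three measured compounds carry an aromatic ring on that nitrogen, so the data contain no precedent for an octyl chain there.

For the measured compounds named here, no step between measured compounds differing in one place is available, and the size of this step in this assay cannot be derived from the data. At most a modest move towards stronger inhibition is expected, ending near the single number shown by compound 2 at 117000 nM. A result with no number remains about as likely as a measured value.

For compound 4 the expected value is 80000 nM, with an estimated range from 20000 nM to 250000 nM.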

Compound 4, half-maximal inhibitory concentration: 7090 nM
Compound 4: middle estimate off by 11-fold (1.05 log units), on the high side; measured number below the stated range.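

No step can be read from compound 1 to compound 4: in this assay compound 1 gives "not active" (no number reported) and carries no number, while compound 4 gives 7090 nM as a measured value. The compounds shown leave open how large the change is on going from 4-methoxy-2-nitrophenyl to octyl on the aromatic nitrogen. No measured evidence bears on this result.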